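The step from compound 2 to compound 3

The source may hold more compounds than are shown below. What is called first, only, known or untested is meant among the compounds shown, and "the series" means these compounds.

Measured so far in a functional assay on HFF cells (Homo sapiens) for cytotoxicity; on this read-out lower numbers stand for stronger inhibition and higher numbers for weaker inhibition:
- compound 1 `Cc1ccc(/C=C2\SC(=S)N(NS(=O)(=O)c3ccccc3)C2=O)cc1`: > 100000 nM
- compound 2 `O=C1/C(=C/c2ccc(Cl)c(F)c2)SC(=S)N1NS(=O)(=O)c1ccccc1`: > 100000 nM

Both entries are limits of the assay, not numbers. Compound 2 stands at > 100000 nM, which tells only a limit. Compound 3 `O=C1/C(=C/c2ccc(Br)c(Br)c2)SC(=S)N1NS(=O)(=O)c1ccccc1` is still unmeasured, and it differs from compound 2 as follows: 3,4-dibromophenyl in place of 4-chloro-3-fluorophenyl on a double-bonded chain carbon bound to a double-bonded ring carbon. Among the measured compounds shown here, the one measured step at this place is a step that the two limits leave unreadable from compound 1 to compound 2, and its size cannot be read. The evidence amounts to the limit of > 100000 nM in this assay, at which 2 of the 2 values shown sit. In this assay no step beyond the scatter is therefore expected, and no direction. The expected change is a number no higher from compound 2 to compound 3 (the limit leaves the size open). For compound 3 the estimated value is 100000 nM, with an expected range from 40000 nM to 150000 nM.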

Compound 3, half-maximal inhibitory concentration: > 100000 nM
Compound 3: a limit, no number; the forecaster's own chance of this, stated with the estimate: 80%; the middle value lies on the limit itself.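

In this assay compound 3 gives > 100000 nM as a limit and not a number. Among the compounds shown here, no step among compound 1, compound 2 and compound 3 can be read. The compounds shown leave open whether 4-methylphenyl, 4-chloro-3-fluorophenyl and 3,4-dibromophenyl differ at all on this read-out.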